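Swapping an Aryl Amine for a Cyclohexyl Amine

This account rests on a few compounds, and the source may have more. Where it says the series, first, only, none or still open, it means among the compounds named here.

Measured compounds:
- Compound 1 `CCCc1ccc(NC2=CC(=O)c3c(nc4n3[C@H]3OC[C@@H](O)[C@H]3OC4)C2=O)cc1`: 1920 nM
- Compound 2 `CCc1ccc(NC2=CC(=O)c3nc4n(c3C2=O)[C@H]2OC[C@@H](O)[C@H]2OC4)cc1`: 1290 nM
- Compound 3 `O=C1C=C(Nc2ccc(C(F)(F)F)cc2)C(=O)c2c1nc1n2[C@H]2OC[C@@H](O)[C@H]2OC1`: 2820 nM

All three compounds share one core and differ only in the group attached to the amine nitrogen. In a functional assay on MGC-803 cells (Homo sapiens) for inhibition, read by sulforhodamine B assay (on this read-out lower numbers stand for stronger inhibition and higher numbers for weaker inhibition), compound 1 gives 1920 nM, which places it second highest of the three numbers. Its gaps to compound 3 and to compound 2 are both within the usual scatter, so the three compounds are not separated in a meaningful way. Among the measured compounds shown here, the only single-site step among them is a 2.2-fold higher number from compound 2 to compound 3 (0.34 log units; beyond the scatter).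

Compound 4 `O=C1C(NC2CCCCC2)=CC(=O)c2c1nc1n2[C@H]2OC[C@@H](O)[C@H]2OC1` is the unmeasured compound. Compared with compound 1, the change is cyclohexyl in place of 4-propylphenyl on an amine nitrogen. For the measured compounds named here, no measured step involves this kind of exchange: the one recorded step keeps the aromatic ring and only alters the group on it, and is modest in size. There is therefore no direct guide to the direction or size of the step in this assay, and the estimate rests on the narrow spread of the three measured numbers around compound 1.

The value for compound 4 is expected to be 3000 nM, with a range from 1000 nM to 10000 nM, meaning an expected step of a 1.6-fold higher number from compound 1 to compound 4 (0.19 log units; within the scatter).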

Compound 4, half-maximal inhibitory concentration: > 8000 nM
Compound 4 ended at the assay's limit; the forecaster's own chance of this, stated with the estimate: 10%; at least 2.6-fold (0.42 log units) between middle value and limit.
By their numbers in this assay, from the lowest: compounds 2, 1 and 3 (each within the scatter of the next, the first and the last beyond it). At a limit, above all of these: compound 4.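

In this assay compound 4 gives > 8000 nM, which is a limit of the assay and not a number. Changing only the group carried on the aromatic ring had a modest effect, with a 2.2-fold higher number from compound 2 to compound 3 (0.34 log units; beyond the scatter), whereas replacing the whole 4-propylphenyl with cyclohexyl gives an at least 4.1-fold higher number from compound 1 to compound 4 (0.61 log units; beyond the scatter). This single pair shows that the group on the amine nitrogen can matter in this assay, and that here a non-aromatic ring does not stand in for the substituted aromatic one without a clear weakening of inhibition.

The change removes both the aromatic character of the ring and the propyl chain, so the compounds shown leave open which of the two accounts for the weaker inhibition, and the limit leaves the full size of the step unknown. A plain phenyl group or a 4-propylcyclohexyl group on the same nitrogen would help tell these two apart, since each would change only one of them.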